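A Benzofuran in Place of Furan

The source may report more compounds than this note shows. Statements on the series, on what has been measured and on what is new or still open speak of the compounds shown alone.

In a functional assay on HepG2 cells (Homo sapiens) for antiproliferative activity, read by XTT assay, with a stated time of 72 h (on this read-out lower numbers stand for stronger inhibition and higher numbers for weaker inhibition), compound 1 `COc1ncnc2c1c(-c1cc3ccccc3o1)cn2[C@@H]1O[C@H](CO)[C@@H](O)[C@H]1O` is reported only as a limit of the assay, > 20000 nM. Going by the values given here, compound 2 `Cc1ncnc2c1c(-c1ccoc1)cn2[C@@H]1O[C@H](CO)[C@@H](O)[C@H]1O` gives 5320 nM, the only actual number so far. Compound 3 `Cc1ncnc2c1c(-c1cc3ccccc3o1)cn2[C@@H]1O[C@H](CO)[C@@H](O)[C@H]1O` has not yet been measured. It carries 1-benzofuran-2-yl in place of furan-3-yl on an aromatic carbon of the shared core: 1-benzofuran-2-yl in place of furan-3-yl on an aromatic carbon. Among the compounds with values here, no measured step isolates this change, so the only guide is compound 1, which bears the same 1-benzofuran-2-yl group and sits at the limit of > 20000 nM. A move beyond the usual scatter towards weaker inhibition in this assay is therefore expected, though not a large one. The estimated 2.6-fold higher number from compound 2 to compound 3 (0.42 log units; beyond the scatter) reflects this. For compound 3, the expected value is 14000 nM, with an estimated range of 5000 nM to 40000 nM.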

Compound 3, half-maximal inhibitory concentration: > 20000 nM
Compound 3: only a limit was reported (the forecaster's own chance of this, stated with the estimate: 45%); at least 1.4-fold (0.15 log units) between middle value and limit.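

Going by these compounds alone, on the shared core, 1-benzofuran-2-yl in place of furan-3-yl on an aromatic carbon gives an at least 3.7-fold higher number from compound 2 to compound 3 (0.57 log units; beyond the scatter) in this assay, the first step that isolates a change at this position, and it runs towards weaker inhibition. That size is only a lower bound because the value of compound 3 is a limit: the limit of > 20000 nM in this assay, at which 2 of the 3 values shown sit. The step from compound 1 to compound 3 cannot be read, as both values are limits, so the exchange of methoxy for methyl shows nothing here.

The compounds shown leave open whether the weaker inhibition follows from the added six-membered aromatic ring of carbon only or from the change from furan-3-yl to a 2-yl attachment, which furan-2-yl on the same core would separate. As far as these compounds go, how an amine or a carboxylic acid on the 1-benzofuran-2-yl group would read in this assay also remains open.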